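Methoxy for ethyl on the urea aryl ring

The source may hold more compounds than are shown below. What is called first, only, known or untested is meant among the compounds shown, and "the series" means these compounds.

Measured so far:
compound 1, `CCc1cccc(NC(=O)N[C@H](C)c2ccccc2)c1`, gives 97% in an ADME assay on the whole organism with Oryza sativa as the target, tested at 0.1 uM; a higher number here means a weaker effect of the compound at the concentration tested, a lower number a stronger effect.
compound 2, `CCc1cccc(NC(=O)N[C@@H](C)c2ccccc2)c1`, gives 100% in this assay.

Compound 2 stands highest of the two numbers in this assay, its nearest neighbour being compound 1 with a number a number 3 percentage points higher from compound 1 to compound 2 (within the scatter). Going by the values given here, the only measured step is this pair, and the fact that compounds 1 and 2 differ only in the configuration as drawn is all that separates them; it says nothing about substitution on the aromatic ring.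

Compound 3, `COc1cccc(NC(=O)N[C@@H](C)c2ccccc2)c1`, differs from compound 2 by methoxy in place of ethyl on an aromatic carbon. Among the compounds with values here, no measured step bears on this change, so there is no basis for expecting a shift beyond the scatter in this assay in either direction. Compound 3 is therefore expected to sit close to compound 2, with an estimated step of a number 2 percentage points lower from compound 2 to compound 3 (within the scatter). For compound 3 the estimate in this assay is 98%, ranging from 88% to 100%.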

Compound 3, a percentage reported as activity, at one concentration (the size of the read-out at that concentration, not a potency): 101%
The estimate for compound 3 lay 3 percentage points below the measured number; measured number outside the range, above it.
By their numbers in this assay, from the lowest: compounds 1, 2 and 3 (each within the scatter of the next).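

Within this assay the exchange of ethyl for methoxy on an aromatic carbon, meta to a large group, brings a number 1 percentage points higher from compound 2 to compound 3 (within the scatter) and so adds a second kind of step to the one between the two configurations. Going by these compounds alone, it is the first measured change at this ring position, and replacing a carbon with an oxygen, which adds a hydrogen-bond acceptor, gives no step beyond the scatter at the single concentration tested. Nothing available speaks to the reason for this result.

The compounds shown leave open whether an amine, a carboxylic acid or a longer chain on this aromatic carbon would give a step beyond the scatter. They also leave open whether methoxy would read the same when paired with the configuration of compound 1.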